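The source may report more compounds than this note shows. Statements on the series, on what has been measured and on what is new or still open speak of the compounds shown alone.

Among the measured compounds shown here, in a functional assay on A549 cells (Homo sapiens) for inhibition, read by CCK-8 assay, with a stated time of 48 h (a lower number here means a stronger inhibitor, a higher number a weaker inhibitor), compound 1 `COc1cc(-c2ccnc3cc(-c4ccc5cc[nH]c5c4)nn23)cc(OC)c1OC` gives 170 nM and compound 2 `COc1ccc(-c2cc3nccc(-c4cc(OC)c(OC)c(OC)c4)n3n2)cc1F` gives 545 nM, so compound 2 holds the higher of the two numbers so far. Compound 3 `COc1cc(-c2ccnc3cc(-c4ccc(C(C)(C)C)cc4)nn23)cc(OC)c1OC` has not yet been measured. It keeps the shared core of compound 2 and differs on an aromatic carbon of the five-membered aromatic ring: 4-(tert-butyl)phenyl in place of 3-fluoro-4-methoxyphenyl on an aromatic carbon. For the measured compounds named here, one measured step bears on this place, the exchange of 1H-indol-6-yl for 3-fluoro-4-methoxyphenyl, and it is modest: a 3.2-fold higher number from compound 1 to compound 2 (0.51 log units; beyond the scatter). Going by the values given here, no measured compound carries 4-(tert-butyl)phenyl, so the direction rests on little. A step within the scatter is expected, with a slight lean towards a higher number, though a modest move either way would not surprise. The expected step is a 1.3-fold higher number from compound 2 to compound 3 (0.11 log units; within the scatter). For compound 3 the estimated value is 700 nM, with an expected range of 200 nM to 2500 nM.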

Compound 3, half-maximal inhibitory concentration: > 10000 nM
Compound 3: a limit, no number; the forecaster's own chance of this, stated with the estimate: 5%; middle value at least 14-fold (1.15 log units) from the limit.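

In this assay, this aromatic carbon of the five-membered ring proves far less forgiving than the earlier modest step suggested: 4-(tert-butyl)phenyl in place of 3-fluoro-4-methoxyphenyl gives an at least 18-fold higher number from compound 2 to compound 3 (1.26 log units; beyond the scatter), and in place of 1H-indol-6-yl it gives an at least 58-fold higher number from compound 1 to compound 3 (1.76 log units; beyond the scatter). The choice of aryl group here can therefore carry a compound from a measurable potency to the top of the assay's range, even with the rest of the structure unchanged. The reading for compound 3 is a limit and not a number: the limit of > 10000 nM in this assay, at which 1 of the 3 values shown sits.

Going by these compounds, the true size of the loss stays unknown, and three aryl groups cannot show whether the tert-butyl group itself or the absence of the methoxy and fluorine substituents matters. A 4-methylphenyl or 4-aminophenyl group at this position would help to separate these possibilities.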